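Cyclohexyl for sec-Butyl on the Amine-Side Chain

This account rests on a few compounds, and the source may have more. Where it says the series, first, only, none or still open, it means among the compounds named here.

Among the compounds with values here, compound 2 `CCC(C)CNCCN(C(=O)[C@@H]1C[C@H]1c1ccccc1)c1ccc(-c2ccccc2)cc1` gives 4.7 nM in a functional assay for agonist activity at G protein-coupled receptor 88 (Homo sapiens), read by HTRF and cAMP accumulation (a lower number here means that less compound is needed, a higher number that more compound is needed for the effect), the higher of the two numbers measured so far. Compound 1 `CO[C@H](C)[C@H](N)CN(C(=O)[C@@H]1C[C@H]1c1ccccc1)c1ccc(-c2ccccc2)cc1` gives 0.68 nM in this assay. Within the data shown here, the only measured step, a 6.9-fold higher number from compound 1 to compound 2 (0.84 log units; beyond the scatter), concerns the saturated chain carbon bound to the amide-type nitrogen, not the amine side, so it offers no direct precedent. Compound 3 `O=C([C@@H]1C[C@H]1c1ccccc1)N(CCNCC1CCCCC1)c1ccc(-c2ccccc2)cc1` differs from compound 2 by cyclohexyl in place of sec-butyl on a saturated chain carbon bound to an amine nitrogen. With no guidance at this position, the step of a 1.0-fold lower number from compound 2 to compound 3 (0.02 log units; within the scatter) is expected to be small. The estimate for compound 3 is 4.5 nM, between 1.5 nM and 15 nM.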

Compound 3, half-maximal effective concentration: 6.6 nM
Beside the measured number, compound 3's estimate is 1.5-fold (0.17 log units) below it; the measured number falls inside the stated range.
By their numbers in this assay, from the lowest: compound 1; then compounds 2 and 3 (each within the scatter of the next).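

In this assay cyclohexyl in place of sec-butyl on a saturated chain carbon bound to an amine nitrogen gives a 1.4-fold higher number from compound 2 to compound 3 (0.15 log units; within the scatter) so this ring and this open chain are not told apart here. The other step, a 9.7-fold higher number from compound 1 to compound 3 (0.99 log units; beyond the scatter) shows that compound 3, like compound 2, stays beyond the scatter from compound 1. No evidence at hand bears on this result. The compounds shown leave open whether a phenyl group at this place, or an amine or hydroxyl on the cyclohexyl ring, would shift the number.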